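From 4-cyanophenyl to 2-fluorophenyl at an assay limit

A few compounds are considered here, and "the series" means these few. Any claim that something is new, unique, unknown or untested is made for them only; others in the source may bear on it.

Compound 1 (`COC(=O)CC/C(C)=C/Cc1c(OC)c(C)c2c(c1OCC#CCN1CCN(c3ccc(C#N)cc3)CC1)C(=O)OC2`) has been tested in a functional assay on MDA-MB-231 cells (Homo sapiens) for inhibition, read by sulforhodamine B assay; on this read-out lower numbers stand for stronger inhibition and higher numbers for weaker inhibition. In this test compound 1 gives > 50000 nM, which is a limit of the assay and not a number. Compound 2 (`COC(=O)CC/C(C)=C/Cc1c(OC)c(C)c2c(c1OCC#CCN1CCN(C(c3ccc(F)cc3)c3ccc(F)cc3)CC1)C(=O)OC2`) gives > 50000 nM, which is also a limit. Compound 1 therefore has no exact position on the scale, and the data so far amount to the limit of > 50000 nM in this assay, at which 2 of the 2 values shown sit.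

Compound 3 (`COC(=O)CC/C(C)=C/Cc1c(OC)c(C)c2c(c1OCC#CCN1CCN(c3ccccc3F)CC1)C(=O)OC2`) carries 2-fluorophenyl in place of 4-cyanophenyl on an amine nitrogen in a ring, and the change counts as 2-fluorophenyl in place of 4-cyanophenyl on an amine nitrogen in a ring. For the measured compounds named here, no measured pair shows what this swap does. The estimated step, a step that the limit leaves unreadable from compound 1 to compound 3, is expected to stay within the usual scatter of this assay. For compound 3 the expected value is 55000 nM, with an estimated range from 25000 nM to 100000 nM.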

Compound 3, half-maximal inhibitory concentration: > 50000 nM
Compound 3: a limit, no number; the forecaster's own chance of this, stated with the estimate: 75%; the middle value lies beyond the limit too.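

Compound 1 and compound 3 both sit at a limit, so the swap from 4-cyanophenyl to 2-fluorophenyl gives no readable step between them: the limit of > 50000 nM in this assay, at which 3 of the 3 values shown sit.

The compounds shown leave open what exact value any of them has, and whether 2-fluorophenyl and 4-cyanophenyl differ at all in this test.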